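Chloro added to the core of compound 3

A few compounds are considered here, and "the series" means these few. Any claim that something is new, unique, unknown or untested is made for them only; others in the source may bear on it.

Measured so far:
compound 1 `ClCc1ccccc1Cn1cnc2c(Cl)nc(Cl)nc21`: > 100000 nM
compound 2 `ClCc1cccc(Cn2cnc3ncnc(Cl)c32)c1`: 2880 nM
compound 3 `ClCc1cccc(Cn2cnc3c(Cl)ncnc32)c1`: > 100000 nM

In a functional assay on T47D cells (Homo sapiens) for cytotoxicity, read by sulforhodamine B assay, with a stated time of 48 h (on this read-out higher numbers stand for lower toxicity in this test and lower numbers for higher toxicity in this test), compound 3 gives only a limit, > 100000 nM. Compound 1 likewise gives only a limit, > 100000 nM. Within the data shown here, the one numerical value comes from compound 2, which gives 2880 nM; compound 2 and compound 3 are made of the same pieces joined differently, and no step between them is counted here. What is known of the set is the limit of > 100000 nM in this assay, at which 2 of the 3 values shown sit.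

Compound 4 `ClCc1cccc(Cn2cnc3c(Cl)nc(Cl)nc32)c1` is not yet measured. It differs from compound 3 by chloro in place of hydrogen on an aromatic carbon. Compound 1 already carries two chloro groups on its core and sits at the limit, so no step beyond the scatter toward higher toxicity is expected; the expected step is a number no higher from compound 3 to compound 4 (the limit leaves the size open), most likely none that the assay can resolve. The expected value for compound 4 is 100000 nM, within 20000 nM to 300000 nM, with a good chance that again only a limit is reported.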

Compound 4, concentration lethal to 50% of the cells: > 100000 nM
Compound 4: only a limit was reported; the forecaster's own chance of this, stated with the estimate: 70%; the middle value lies on the limit itself.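

In this assay compound 4 gives only a limit, > 100000 nM. Among these compounds, compound 3 gives the same limit, > 100000 nM, so no step between compound 3 and compound 4 can be read. The compounds shown leave open whether chloro in place of hydrogen on an aromatic carbon changes cytotoxicity at all in this assay.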